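A few compounds are considered here, and "the series" means these few. Any claim that something is new, unique, unknown or untested is made for them only; others in the source may bear on it.

Compound 1 `CC(C(=O)NCc1ccc(C(F)(F)F)nc1)c1ccc(NS(C)(=O)=O)c(F)c1` — a functional assay on CHO-K1 cells for antagonist activity at transient receptor potential cation channel subfamily V member 1 (Homo sapiens), read by FLIPR; a higher number here means a weaker inhibitor, a lower number a stronger inhibitor: "not active" (no number reported)
Compound 2 `CC(C(=O)NCc1ccc(C(F)(F)F)nc1NCc1ccccc1)c1ccc(NS(C)(=O)=O)c(F)c1` — 203 nM
Compound 3 `CC(C(=O)NCc1ccc(C(F)(F)F)nc1N1CCCC1)c1ccc(NS(C)(=O)=O)c(F)c1` — 211 nM

Compound 1 is reported without a number in this assay. Among the two numbers, compound 3 has the highest, and its nearest neighbour is compound 2, from which it is separated only by a 1.0-fold higher number from compound 2 to compound 3 (0.02 log units; within the scatter). Compound 4 `CC(C(=O)NCc1ccc(C(F)(F)F)nc1N1CCC(O)CC1)c1ccc(NS(C)(=O)=O)c(F)c1` is not yet measured; it differs from compound 3 as follows: 4-hydroxypiperidin-1-yl in place of pyrrolidin-1-yl on an aromatic carbon. Within the data shown here, the only step that bears on this change is the one from compound 2 to compound 3, which swapped one amine for another at the same aromatic carbon and stayed within the scatter. Compound 4 is therefore expected to give 250 nM, with a range of 100 nM to 650 nM. The expected step is a 1.2-fold higher number from compound 3 to compound 4 (0.07 log units; within the scatter), not beyond the scatter.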

Compound 4, half-maximal inhibitory concentration: "not active" (no number reported)
Nothing numeric was reported for compound 4; no gap can be computed for the estimate.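

Among these compounds, compound 4 carries no number in this assay, and no step from compound 3 to it can be read. No measured evidence bears on this result. The compounds shown leave open whether the missing number reflects the 4-hydroxypiperidin-1-yl group itself.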